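The compounds below may be only part of what the source reports. "The series", "measured", "known", "first", "only" and "open" are said of these compounds alone.

Three compounds share one core, and all three were tested in a functional assay on BXPC-3 cells (Homo sapiens) for inhibition, read by MTT assay, with a stated time of 72 h; a higher number here means a weaker inhibitor of growth, a lower number a stronger inhibitor of growth. Compound 1 `O=S(=O)(NCCCNCc1ccc(Cl)cc1)c1cc(C(F)(F)F)cc(C(F)(F)F)c1` gives 1600 nM, compound 2 `O=S(=O)(NCCNCc1ccc(-c2ccccc2)cc1)c1cc(C(F)(F)F)cc(C(F)(F)F)c1` gives 1600 nM, and compound 3 `CC(C)(C)c1ccc(CNCCCNS(=O)(=O)c2cc(C(F)(F)F)cc(C(F)(F)F)c2)cc1` gives 1400 nM. Compound 1 stands level with compound 2 at the digits reported, the two together holding the highest number of the three, while the step of a 1.1-fold lower number from compound 1 to compound 3 (0.06 log units; within the scatter) stays within the scatter. Compound 4 `O=S(=O)(NCCCNCc1cccc(Cl)c1)c1cc(C(F)(F)F)cc(C(F)(F)F)c1` differs from compound 1 by 3-chlorophenyl in place of 4-chlorophenyl on a saturated chain carbon bound to an amine nitrogen. Within the data shown here, no measured step moves a chloro substituent around its ring; the only step on that ring, a 1.1-fold lower number from compound 1 to compound 3 (0.06 log units; within the scatter), changed little. I therefore expect no movement beyond the scatter, and estimate compound 4 at 1600 nM, between 800 nM and 3200 nM, a step of no change at the digits printed from compound 1 to compound 4 (within the scatter).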

Compound 4, concentration for 50% growth inhibition: 3800 nM
Compound 4: middle estimate off by 2.4-fold (0.38 log units), on the low side, and the stated range ends below it.
By their numbers in this assay, from the lowest: compounds 3, 1 and 2 (each within the scatter of the next); then compound 4.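

In this assay, the place of the chlorine on the ring matters: 3-chlorophenyl in place of 4-chlorophenyl, with the same atoms, gives a 2.4-fold higher number from compound 1 to compound 4 (0.38 log units; beyond the scatter), a change beyond the scatter. Replacing 4-(tert-butyl)phenyl with 3-chlorophenyl gives a 2.7-fold higher number from compound 3 to compound 4 (0.43 log units; beyond the scatter), although that step changes both the group and its place on the ring. No available evidence explains this shift. From the compounds shown here alone, it remains open whether fluoro or methoxy would respond in the same way when moved around this ring. An unsubstituted phenyl ring could also show whether chlorine is needed at all.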